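A Second Chloro Group on a Fused Core: Expected Effect

This account rests on a few compounds, and the source may have more. Where it says the series, first, only, none or still open, it means among the compounds named here.

Measured compounds in a functional assay on SNB-75 cells (Homo sapiens) for cytotoxicity, read by sulforhodamine B assay, with a stated time of 48 h; a higher number here means a weaker inhibitor of growth, a lower number a stronger inhibitor of growth:
Compound 1, `ClCc1cccc(Cn2cnc3ncnc(Cl)c32)c1`, gives 3540 nM.
Compound 2, `ClCc1ccccc1Cn1cnc2ncnc(Cl)c21`, gives 26900 nM.
Compound 3, `ClCc1cccc(Cn2cnc3nc(Cl)nc(Cl)c32)c1`, gives 2290 nM.

Compound 1 and compound 2 are built from the same atoms joined differently; the difference between the two cores is not broken down here. Compound 2 stands highest of the three numbers in this assay, and its distance from both compound 1 and compound 3 lies beyond the usual scatter, so it is the weakest inhibitor of growth among the measured set.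

Compound 3 differs from compound 1 by chloro in place of hydrogen on an aromatic carbon, and this gave a 1.5-fold lower number from compound 1 to compound 3 (0.19 log units; within the scatter).

Compound 4, `ClCc1ccccc1Cn1cnc2nc(Cl)nc(Cl)c21`, has not yet been measured. It differs from compound 2 by chloro in place of hydrogen on an aromatic carbon, which is the same change, made at the same kind of place on the core of compound 2.

The step from compound 2 to compound 4 in this assay is expected to be small, a 1.5-fold lower number from compound 2 to compound 4 (0.17 log units; within the scatter), because the same change produced a 1.5-fold lower number from compound 1 to compound 3 (0.19 log units; within the scatter). Compound 4 is therefore estimated at 18000 nM, with a likely range from 7000 nM to 45000 nM.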

Compound 4, concentration for total growth inhibition: 4460 nM
For compound 4 the middle estimate is 4.0-fold (0.61 log units) above the measured one, outside the stated range (below it).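

In this assay, placing a chloro on the aromatic carbon between two ring nitrogen atoms gave a 6.0-fold lower number from compound 2 to compound 4 (0.78 log units; beyond the scatter). Set beside the earlier case, the same change did not carry over at the same size: the same change on two cores in this assay, a 1.5-fold lower number (0.19 log units; within the scatter) from compound 1 to compound 3 and a 6.0-fold lower number (0.78 log units; beyond the scatter) from compound 2 to compound 4, 3.9-fold (0.59 log units) apart, beyond the scatter of two such steps Only the step on the core of compound 2 lies beyond the scatter, so in this series the chloro cannot be treated as a fixed increment that transfers unchanged from one core to another, yet two steps do not show what sets them apart or what the change would do on a third core.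

The compounds shown leave open whether an amine or a methoxy group at that same place would move the number as the chloro does on either core. They also leave open what would follow if the chloromethyl group gave way to a longer chain, and whether the two cores would then differ in the same way.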